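Methoxy to Hydroxy on a Weakly Active Compound

The source may report more compounds than this note shows. Statements on the series, on what has been measured and on what is new or still open speak of the compounds shown alone.

Compound 1, `COc1cc(-c2nn(-c3ccc(NC(=O)Nc4ccc(Cl)c(Cl)c4)cc3)cc2-c2ccncc2)ccc1Cl`, in a functional assay on A375P cells (Homo sapiens) for antiproliferative activity, read by MTT assay, with a stated time of 48 h (a higher number here means a weaker inhibitor, a lower number a stronger inhibitor), gives a limit of the assay, > 20000 nM.
Compound 2, `COc1cc(-c2nn(-c3ccc(NC(=O)c4ccc(Cl)c(Cl)c4)cc3)cc2-c2ccncc2)ccc1Cl`, in this assay gives 13000 nM.

Compound 1 stands at the limit of this assay: the assay returned no number for it, only the limit (the limit of > 20000 nM in this assay, at which 1 of the 2 values shown sits). Compound 2 shares the whole framework apart from the carbonyl carbon, where a 3,4-dichlorophenyl stands in place of (3,4-dichlorophenyl)amino, and the step is an at least 1.5-fold lower number from compound 1 to compound 2 (0.18 log units; that floor lies within the scatter), a difference that itself sits within the usual scatter.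

Compound 3, `O=C(Nc1ccc(-n2cc(-c3ccncc3)c(-c3ccc(Cl)c(O)c3)n2)cc1)Nc1ccc(Cl)c(Cl)c1`, has not yet been measured in this assay. It differs from compound 1 by hydrogen in place of methyl on an oxygen on an aromatic ring, that is, methoxy becomes hydroxy, hydrogen in place of methyl on an oxygen on an aromatic ring. Within the data shown here, no measured step touches this oxygen; the single measured step concerns the carbonyl carbon and so does not bear on it. With no guidance from the measured compounds, no step beyond the scatter is expected, and compound 1 already sits at a limit, so compound 3 is expected to come out about as weak, the expected step being a step that the limit leaves unreadable from compound 1 to compound 3. Compound 3 is therefore estimated at 25000 nM in this assay, with a range from 8000 nM to 80000 nM, and a limit rather than a number is quite possible.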

Compound 3, half-maximal inhibitory concentration: 13500 nM
Estimate against measurement, compound 3: 1.9-fold (0.27 log units) above; the range from low to high includes it.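

The measured step now reaches this oxygen: with hydroxy in place of methoxy on the aromatic ring, compound 3 gives 13500 nM in this assay, a number rather than a limit. The step is an at least 1.4-fold lower number from compound 1 to compound 3 (0.17 log units; that floor lies within the scatter), so the data offer only a floor, and that floor alone does not show that losing the methyl changes the activity at all. The true size of the step cannot be read, because compound 1 stands at a limit: the limit of > 20000 nM in this assay, at which 1 of the 3 values shown sits.

The compounds shown leave open whether the hydrogen on this oxygen matters in itself or whether other groups would read alike, and an ethoxy group, a longer chain on the oxygen or an amine in place of the hydroxy would each put that to the test. They also leave open what methoxy to hydroxy would do on compound 2, where the starting value is a number and no limit would hide the size of the step.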